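A few compounds are considered here, and "the series" means these few. Any claim that something is new, unique, unknown or untested is made for them only; others in the source may bear on it.

Compound 1, `CCCC(=O)C1=C(C)NC(=O)NC1c1ccoc1`: 22%
Compound 2, `CCCC(=O)C1=C(C)NC(=O)NC1c1cccs1`: 9%
Compound 3, `CCCC(=O)C1=C(C)NC(=O)NC1c1ccsc1`: 9%

In an assay on membranes from HEK293 cells for displacement of a labelled ligand from adenosine receptor A2b (Homo sapiens), read by scintillation counting, with a stated time of 30 min, tested at 1 uM (a lower number here means less inhibition, a higher number more inhibition at the concentration tested (going by the name of the read-out)), compound 1 gives the highest of the three numbers; in the same test compound 2 gives 9% and compound 3 gives 9%. Both measured steps away from compound 1 concern the ring on the saturated ring carbon: a number 13 percentage points lower from compound 1 to compound 2 (beyond the scatter) and a number 13 percentage points lower from compound 1 to compound 3 (beyond the scatter), while no change at the digits printed from compound 2 to compound 3 (within the scatter). Compound 4, `CCSC(=O)C1=C(C)NC(=O)NC1c1ccoc1`, is not yet measured. It differs from compound 1 in another place: ethylsulfanyl in place of propyl on a carbonyl carbon. Among the compounds with values here, no measured step touches this carbonyl carbon, so the three measured steps give no direct guide to the size or direction of the change. Since compound 1 starts from a modest number, the expectation for compound 4 is a step of about a number 4 percentage points lower from compound 1 to compound 4 (within the scatter), that is, no firm movement beyond the scatter. Compound 4 is therefore estimated at 18%, with a range from 5% to 35%.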

Compound 4, a percentage reported as inhibition, at one concentration (the size of the read-out at that concentration, not a potency): 1%
Beside the measured number, compound 4's estimate is 17 percentage points above it; measured number outside the range, below it.
By their numbers in this assay, from the lowest: compounds 4, 2 and 3 (each within the scatter of the next); then compound 1.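

Within the data shown here, this is the first measured change on the carbonyl carbon, and it shows that this place matters in this assay: ethylsulfanyl in place of propyl gives a number 21 percentage points lower from compound 1 to compound 4 (beyond the scatter). The two groups have the same count of heavy atoms and neither carries a ring, so a swap that leaves the size of the group by that count unchanged, with sulfur entering the chain, is enough to move the number beyond the scatter. Nothing available explains why the number falls.

The compounds shown leave open whether the drop belongs to the sulfur itself or would also appear with an ethoxy group or an amine on the same carbonyl carbon. They also leave open whether ethylsulfanyl has the same effect when the furan-3-yl ring gives way to thiophen-3-yl.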